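Piperazine nitrogen substituents on the shared core

The source may hold more compounds than are shown below. What is called first, only, known or untested is meant among the compounds shown, and "the series" means these compounds.

The series keeps one core and varies only the group on an amine nitrogen in a ring. In a functional assay on CCRF-CEM cells for agonist activity at C-X-C chemokine receptor type 4 (Homo sapiens), read by calcium flux, with a stated time of 25 min (a higher number here means that more compound is needed for the effect, a lower number that less compound is needed), compound 1 `CN(C[C@H]1Cc2c(cccc2N2CCN(C3COC3)CC2)CN1)[C@H]1CCCc2cccnc21` gives only a limit, > 30000 nM. Compound 2 `CC(C)N1CCN(c2cccc3c2C[C@H](CN(C)[C@H]2CCCc4cccnc42)NC3)CC1` likewise reaches only a limit in this assay, > 30000 nM. Compound 3 `CN(C[C@H]1Cc2c(cccc2N2CCN(Cc3ccccn3)CC2)CN1)[C@H]1CCCc2cccnc21` also stands at a limit in this assay, > 30000 nM. The steps a step that the two limits leave unreadable from compound 1 to compound 2, a step that the two limits leave unreadable from compound 1 to compound 3 and a step that the two limits leave unreadable from compound 2 to compound 3 carry no readable size because of the limit of > 30000 nM in this assay, at which 3 of the 3 values shown sit. Compound 4 `CN(C[C@H]1Cc2c(cccc2N2CCN(c3cccc(C(F)(F)F)c3)CC2)CN1)[C@H]1CCCc2cccnc21` differs from compound 3 by 3-(trifluoromethyl)phenyl in place of (pyridin-2-yl)methyl on an amine nitrogen in a ring. Among the measured compounds shown here, no measured step shows a size or direction, so no change beyond a limit can be anticipated. Compound 4 is expected to give about 40000 nM, within 8000 nM to 200000 nM. The estimated step that the limit leaves unreadable from compound 3 to compound 4 is therefore expected to be essentially flat.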

Compound 4, half-maximal effective concentration: > 30000 nM
Compound 4 ended at the assay's limit; the forecaster's own chance of this, stated with the estimate: 75%; the middle value is on the limit's open side.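

Compound 4 also gives only a limit, > 30000 nM, so its steps from compound 1, compound 2 and compound 3 cannot be read: the limit of > 30000 nM in this assay, at which 4 of the 4 values shown sit.

The compounds shown leave open whether any substituent on this ring nitrogen gives a measurable effect in this assay.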